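This account rests on a few compounds, and the source may have more. Where it says the series, first, only, none or still open, it means among the compounds named here.

Measured so far:
compound 1, `CNC(=O)CCCCCCCn1nc(-c2ccc3oc(N)nc3c2)c2c(N)ncnc21`: 30500 nM
compound 2, `Nc1ncnc2c1c(-c1cnc3[nH]ccc3c1)nn2CCCCCCC(=O)NO`: > 50000 nM

In a functional assay on PLC-PRF-5 cells (Homo sapiens) for inhibition, read by MTT assay, with a stated time of 72 h (a lower number here means a stronger inhibitor, a higher number a weaker inhibitor), compound 1 gives 30500 nM, the only number shown in the series. For compound 2 the read-out is a limit, > 50000 nM. That limit is the limit of > 50000 nM in this assay, at which 1 of the 2 values shown sits. Within the data shown here, no step between measured compounds differing in one place is available, so no measured size of step can be drawn on. Compound 3, `Nc1nc2cc(-c3nn(CCCCC(=O)NO)c4ncnc(N)c34)ccc2o1`, differs from compound 1 by hydroxycarbamoyl in place of 3-(methylcarbamoyl)propyl on a saturated chain carbon, four bonds along the chain from an aromatic nitrogen. The step is expected to be small, within the scatter or at most a modest gain. Compound 3 is estimated at 20000 nM, range 5000 nM to 60000 nM. This corresponds to an expected step of a 1.5-fold lower number from compound 1 to compound 3 (0.18 log units; within the scatter).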

Compound 3, half-maximal inhibitory concentration: 29600 nM
For compound 3 the middle estimate is 1.5-fold (0.17 log units) below the measured one; low and high end bracket the measured number.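

In this assay, among these compounds, the first readable step at this position is a 1.0-fold lower number from compound 1 to compound 3 (0.01 log units; within the scatter): hydroxycarbamoyl in place of 3-(methylcarbamoyl)propyl leaves the number within the scatter. A shorter chain with a different end group therefore gives no measurable change on this core. The value of compound 2 is a limit and not a number, so it adds no step: the limit of > 50000 nM in this assay, at which 1 of the 3 values shown sits.

The change alters chain length and end group at once, and these compounds do not separate the two. On these data alone, how a carboxylic acid at the chain end, or hydroxycarbamoyl on a longer chain, would read remains open.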